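A few compounds are considered here, and "the series" means these few. Any claim that something is new, unique, unknown or untested is made for them only; others in the source may bear on it.

Measured so far:
compound 1 `CC(C)(C)NCc1ccc2c(c1)CCC[C@H]2NC(=O)C[C@@H]1CCCCN1S(=O)(=O)c1ccc(Cl)cc1` — 810 nM
compound 2 `COc1ccc(S(=O)(=O)N2CCCC[C@H]2CC(=O)N[C@@H]2CCCc3cc(CNC(C)(C)C)ccc32)cc1` — 1400 nM
compound 3 `CC(C)(C)NCc1ccc2c(c1)CCC[C@H]2NC(=O)C[C@@H]1CCCCN1S(=O)(=O)c1cccc(Cl)c1` — 73 nM

In a functional assay for inhibition of B1 bradykinin receptor (Homo sapiens), read by calcium flux (a higher number here means a weaker inhibitor, a lower number a stronger inhibitor), compound 3 stands lowest of the three, with an 11-fold lower number from compound 1 to compound 3 (1.05 log units; beyond the scatter) and a 19-fold lower number from compound 2 to compound 3 (1.28 log units; beyond the scatter) both beyond the scatter. Compound 4 `Cc1ccc(S(=O)(=O)N2CCCC[C@H]2CC(=O)N[C@@H]2CCCc3cc(CNC(C)(C)C)ccc32)cc1C(F)(F)F` differs from compound 3 by 4-methyl-3-(trifluoromethyl)phenyl in place of 3-chlorophenyl on a sulfonyl sulfur. Among the compounds with values here, two measured steps bear on this. The move from a 4-chlorophenyl to a 3-chlorophenyl gave an 11-fold lower number from compound 1 to compound 3 (1.05 log units; beyond the scatter), while swapping chloro for methoxy at the 4-position gave a 1.7-fold higher number from compound 1 to compound 2 (0.24 log units; within the scatter). Within the data shown here, compound 4 keeps a substituent at the 3-position, which the data favour, but adds a methyl at the 4-position, for which no step is available. Compound 4 is therefore expected to stay near compound 3 or lose somewhat, with a 2.7-fold higher number from compound 3 to compound 4 (0.44 log units; beyond the scatter) estimated. The expected value for compound 4 in this assay is 200 nM, in a range of 50 nM to 800 nM.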

Compound 4, half-maximal inhibitory concentration: 16 nM
Beside the measured number, compound 4's estimate is 13-fold (1.10 log units) above it, and the stated range ends above it.
By their numbers in this assay, from the lowest: compound 4; then compound 3; then compounds 1 and 2 (each within the scatter of the next).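

On the sulfonyl sulfur, 4-methyl-3-(trifluoromethyl)phenyl in place of 3-chlorophenyl gives a 4.6-fold lower number from compound 3 to compound 4 (0.66 log units; beyond the scatter) in this assay, so this position accepts an aryl group with more heavy atoms, and the 4-methyl does not cancel the gain. Against the groups of the first two compounds, the same group gives an 88-fold lower number from compound 2 to compound 4 (1.94 log units; beyond the scatter) and a 51-fold lower number from compound 1 to compound 4 (1.70 log units; beyond the scatter) on the same read-out. Nothing available explains these gains. The methyl and trifluoromethyl arrive together, so their shares remain unseparated. As far as these compounds go, whether a nitrile, an amine or a carboxylic acid on this ring would keep the gain remains open.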